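Naphthalen-1-yl for 3-methylphenyl: expected tolerance of compound 3

The source may hold more compounds than are shown below. What is called first, only, known or untested is meant among the compounds shown, and "the series" means these compounds.

Measured so far:
Compound 1 `Cc1cccc(C(=O)N(C(=S)OCCN2C(=O)c3ccccc3C2=O)c2ccc(Cl)cc2)c1`: 58000 nM
Compound 2 `Cc1ccc(N(C(=O)c2ccc([N+](=O)[O-])cc2Cl)C(=S)OCCN2C(=O)c3ccccc3C2=O)cc1`: 17000 nM

In an ADME assay on MT4 cells (Homo sapiens) for cytotoxicity, read by MTT assay (a higher number here means that more compound is tolerated, a lower number that less compound is tolerated), compound 1 gives 58000 nM, the highest of the two numbers measured. Compound 2 stands nearest to it with 17000 nM, a lower number that lies beyond the scatter of the measurement. The two compounds differ at several places, so no single structural change can be tied to that gap.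

Compound 3 `O=C1c2ccccc2C(=O)N1CCOC(=S)N(C(=O)c1cccc2ccccc12)c1ccc(Cl)cc1` has not yet been measured. It differs from compound 1 in one place: naphthalen-1-yl in place of 3-methylphenyl on a carbonyl carbon. Going by the values given here, no pair of measured compounds separated by this change exists, so the expected direction rests only on the two numbers known. The expected step from compound 1 to compound 3 is a 1.7-fold lower number from compound 1 to compound 3 (0.22 log units; within the scatter), a modest move toward a lower number, close to the edge of the usual scatter. Compound 3 is therefore estimated at 35000 nM in this assay, with a range from 12000 nM to 90000 nM.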

Compound 3, half-maximal cytotoxic concentration: 6000 nM
Estimate against measurement, compound 3: 5.8-fold (0.77 log units) above, outside the stated range (below it).
By their numbers in this assay, from the lowest: compound 3; then compound 2; then compound 1.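

In this assay, naphthalen-1-yl in place of 3-methylphenyl on the carbonyl carbon gives a 9.7-fold lower number from compound 1 to compound 3 (0.99 log units; beyond the scatter), the first difference here that can be tied to a single structural change. It shows that tolerance in this assay responds to the group at this place, with the rest of compound 1 held constant. Nothing available bears on why the step occurs.

On these data alone, the step comes from one pair on one background, so it remains open whether the same change would give a step of similar size on other backgrounds. As far as these compounds go, it also remains open how a plain phenyl, a naphthalen-2-yl or a pyridine ring at this place would compare, and so whether the second aromatic ring or the particular naphthalen-1-yl group goes with the lower number.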